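A Ring in Place of Carboxy on Compound 2

This account rests on a few compounds, and the source may have more. Where it says the series, first, only, none or still open, it means among the compounds named here.

In a functional assay on HEL 299 cells (Homo sapiens) (a higher number here means a weaker inhibitor, a lower number a stronger inhibitor), compound 1 `COC(=O)c1nn([C@@H]2O[C@H](CO)[C@@H](O)[C@H]2O)cc1I` gives 4000 nM. Compound 2 `O=C(O)c1nn([C@@H]2O[C@H](CO)[C@@H](O)[C@H]2O)cc1I` has no number there, only a limit of > 300000 nM. Compound 3 `Cc1noc(-c2nn([C@@H]3O[C@H](CO)[C@@H](O)[C@H]3O)cc2I)n1` keeps the core of compound 2 and carries 3-methyl-1,2,4-oxadiazol-5-yl in place of carboxy on an aromatic carbon. Within the data shown here, one measured step bears on this change: replacing the methyl of the ester with hydrogen gave an at least 75-fold higher number from compound 1 to compound 2 (1.87 log units; beyond the scatter), a large change beyond the scatter. Compound 3, like compound 1, has no carboxy, so a large step to a lower number, and thus a stronger inhibitor, is expected in this assay. The expected change is an at least 50-fold lower number from compound 2 to compound 3 (1.69 log units; beyond the scatter). For compound 3 the estimated value is 6000 nM, with an expected range of 1200 nM to 40000 nM.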

Compound 3, half-maximal inhibitory concentration: 7900 nM
For compound 3 the middle estimate is 1.3-fold (0.12 log units) below the measured one; measured number inside the range.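

In this assay, the step of an at least 37-fold lower number from compound 2 to compound 3 (1.57 log units; beyond the scatter) shows that the carboxy can be replaced at this aromatic carbon by a ring, not only by the methoxycarbonyl of compound 1. The comparison with the ester gives a 2.0-fold higher number from compound 1 to compound 3 (0.30 log units; within the scatter), which lies within the scatter, so 3-methyl-1,2,4-oxadiazol-5-yl and methoxycarbonyl cannot be told apart at this position in this assay. Compound 2 has a limit and not a number, so the step from it gives a bound only: the limit of > 300000 nM in this assay, at which 1 of the 3 values shown sits.

The compounds shown leave open whether the methyl on the new ring matters, which an ethyl group or a hydrogen in its place could test. They also leave open how a primary amide or a tetrazole would compare at this aromatic carbon, and whether the iodo group on the neighbouring ring atom affects the outcome.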